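From compound 2 to compound 3: an added amide substituent

The compounds below may be only part of what the source reports. "The series", "measured", "known", "first", "only" and "open" are said of these compounds alone.

Measured so far in a physicochemical assay for solubility, read by HPLC, with a stated time of 20 h, at pH 1; a lower number here means a less soluble compound, a higher number a more soluble compound
Compound 1 `O=C(Nc1nc(Cc2cc(F)cc(F)c2)no1)c1ccc(O[C@H]2CC[C@@H](C(=O)O)CC2)cc1` gives < 2000 nM
Compound 2 `NC(=O)C[C@H]1CC[C@H](c2ccc(C(=O)Nc3nnc(Cc4ccccc4)s3)cc2)CC1` gives < 2000 nM

Neither entry is an exact number, and each is a limit of the assay. Compound 2 stands only at a limit (< 2000 nM) and has no exact value. The evidence so far amounts to the limit of < 2000 nM in this assay, at which 2 of the 2 values shown sit, and nothing more.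

Compound 3 `CC(C)(O)CNC(=O)C[C@H]1CC[C@H](c2ccc(C(=O)Nc3nnc(Cc4ccccc4)s3)cc2)CC1` differs from compound 2 in one place. It carries 2-hydroxy-2-methylpropyl in place of hydrogen on an amide-type nitrogen. The entering group has no ring and no net charge.

Among the measured compounds shown here, no measured pair of compounds shows what a change of this kind does in this assay and the data offer no direction for it. For the measured compounds named here, the only anchor is compound 2 with its limit (< 2000 nM), so the expectation stays close to that mark. The expected size of the change is a step that the limit leaves unreadable from compound 2 to compound 3 (an estimate of no step beyond the usual scatter). Another reading at a limit is also expected to be quite likely. For compound 3 the estimated solubility is 1500 nM (expected range 500 nM to 4000 nM).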

Compound 3, solubility: < 2000 nM
Compound 3: only a limit was reported; the forecaster's own chance of this, stated with the estimate: 70%; the middle value does not contradict the limit.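

No step can be read from compound 2 to compound 3 in this assay because both readings are limits and not numbers: the limit of < 2000 nM in this assay, at which 3 of the 3 values shown sit.

The compounds shown leave open whether 2-hydroxy-2-methylpropyl in place of hydrogen on the amide-type nitrogen changes the read-out at all, and what exact solubility each of the three compounds has.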